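The source may report more compounds than this note shows. Statements on the series, on what has been measured and on what is new or still open speak of the compounds shown alone.

The study concerns inhibitors of an assay on isolated protein for inhibition of DNA topoisomerase 1 (Homo sapiens), with a stated time of 15 min; a lower number here means a stronger inhibitor, a higher number a weaker inhibitor. Compound 1 `COc1c(N2CC[C@@H](CO)C2)c(F)cc2c(=O)c(C(=O)O)cn(Cc3ccc(-c4ccccc4)cc3)c12` gives in this assay only a limit, > 200000 nM. Compound 2 `COc1c(N2CC[C@@H](CN)C2)c(F)cc2c(=O)c(C(=O)O)cn(Cc3ccc(-c4ccccc4)cc3)c12` gives in this assay 26000 nM, so the step of an at least 7.6-fold lower number from compound 1 to compound 2 (0.88 log units; beyond the scatter) is at least modest. Compound 3 `COc1c(N2CC[C@@H](CN)C2)c(F)cc2c(=O)c(C(=O)O)cn(Cc3ccc(-n4cccn4)cc3)c12` returns in this assay only a limit, > 200000 nM. The step of an at least 7.6-fold higher number from compound 2 to compound 3 (0.88 log units; beyond the scatter) is therefore also at least modest, and compound 3 stands together with compound 1 at the limit of > 200000 nM in this assay, at which 2 of the 3 values shown sit. Compound 4 `COc1c(N2CC[C@@H](CN)C2)c(F)cc2c(=O)c(C(=O)O)cn(Cc3cc(-c4ccccc4)no3)c12` differs from compound 3 by 3-phenyl-1,2-oxazol-5-yl in place of 4-(1H-pyrazol-1-yl)phenyl on a saturated chain carbon bound to an aromatic nitrogen. For the measured compounds named here, no measured step covers this exchange; the only step that touches the same part of the molecule is an at least 7.6-fold higher number from compound 2 to compound 3 (0.88 log units; beyond the scatter), and it showed that this region can move the number by at least a modest amount. Because compound 3 sits at the limit of > 200000 nM in this assay, at which 2 of the 3 values shown sit, the true size of any step from it cannot be fixed, and compound 4 is expected to remain weak, with the estimated step being an at least 1.3-fold lower number from compound 3 to compound 4 (0.12 log units; that floor lies within the scatter). Compound 4 is expected to give in this assay about 150000 nM, with a range from 40000 nM to 600000 nM.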

Compound 4, half-maximal inhibitory concentration: 178000 nM
Beside the measured number, compound 4's estimate is 1.2-fold (0.07 log units) below it; the range from low to high includes it.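

In this assay, compound 4 gives a number rather than a limit, so an exchange of the 4-phenylphenyl group at this position can now be sized: replacing it with 3-phenyl-1,2-oxazol-5-yl gives a 6.8-fold higher number from compound 2 to compound 4 (0.84 log units; beyond the scatter). Against the 4-(1H-pyrazol-1-yl)phenyl group, the change can be stated only as an at least 1.1-fold lower number from compound 3 to compound 4 (0.05 log units; that floor lies within the scatter), and this floor sets no order between the two compounds. The true size of that step stays unknown because the value of compound 3 is a limit: the limit of > 200000 nM in this assay, at which 2 of the 4 values shown sit.

The compounds shown leave open whether a simple benzyl group, or one carrying an amine or a carboxylic acid, would keep the number of compound 2. For the compounds shown here, the exchange of hydroxy for amino is also seen only with 4-phenylphenyl, so its effect alongside 3-phenyl-1,2-oxazol-5-yl remains unknown.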